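Triazole to Tetrazole on the Thioether of Compound 3

A few compounds are considered here, and "the series" means these few. Any claim that something is new, unique, unknown or untested is made for them only; others in the source may bear on it.

Measured in a functional assay on C6 cells (Rattus norvegicus) for cytotoxicity, read by MTT assay, with a stated time of 24 h, tested at 25 ug/mL; on this read-out higher numbers stand for a weaker effect at the one concentration tested and lower numbers for a stronger effect:
Compound 1 `Cc1ccc(-c2cs/c(=N/NC(=O)CSc3nncn3C)n2-c2ccccc2)cc1` gives 70.7%.
Compound 2 `Cc1ccc(-c2cs/c(=N/NC(=O)CSc3nnnn3C)n2-c2ccccc2)cc1` gives 60.7%.
Compound 3 `Cn1cnnc1SCC(=O)N/N=c1/scc(-c2ccc(C#N)cc2)n1-c1ccccc1` gives 58.8%.

Compound 3 lies within the scatter of compound 2, while the step of a number 11.9 percentage points lower from compound 1 to compound 3 (beyond the scatter) is beyond it. Compound 4 `Cn1nnnc1SCC(=O)N/N=c1/scc(-c2ccc(C#N)cc2)n1-c1ccccc1` differs from compound 3 by 1-methyl-1H-tetrazol-5-yl in place of 4-methyl-4H-1,2,4-triazol-3-yl on a sulfur. Among the measured compounds shown here, the one measured step of this same kind is a number 10 percentage points lower from compound 1 to compound 2 (within the scatter), which stays within the scatter. For the measured compounds named here, only one such pair is known, so the evidence is thin, but it suggests that the same change made on compound 3 should not move the read-out in this assay beyond the scatter either. Compound 4 is therefore expected to give about 53%, between 40% and 68%, corresponding to an estimated step of a number 5.8 percentage points lower from compound 3 to compound 4 (within the scatter).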

Compound 4, a percentage reported as activity, at one concentration (the size of the read-out at that concentration, not a potency): 43.9%
Compound 4: middle estimate off by 9.1 percentage points, on the high side; the measured number falls inside the stated range.
By their numbers in this assay, from the lowest: compound 4; then compounds 3, 2 and 1 (each within the scatter of the next, the first and the last beyond it).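

In this assay, 1-methyl-1H-tetrazol-5-yl in place of 4-methyl-4H-1,2,4-triazol-3-yl on a sulfur now gives a number 14.9 percentage points lower from compound 3 to compound 4 (beyond the scatter), so this change can exceed the scatter, yet its two steps still agree: the same change on two cores in this assay, a number 10 percentage points lower (within the scatter) from compound 1 to compound 2 and a number 14.9 percentage points lower (beyond the scatter) from compound 3 to compound 4, 4.9 percentage points apart, within the scatter of two such steps. Cyano in place of methyl on an aromatic carbon also carries over to the second sulfur substituent, with a number 16.8 percentage points lower from compound 2 to compound 4 (beyond the scatter): the same change on two cores in this assay, a number 11.9 percentage points lower (beyond the scatter) from compound 1 to compound 3 and a number 16.8 percentage points lower (beyond the scatter) from compound 2 to compound 4, 4.9 percentage points apart, within the scatter of two such steps. The compounds shown leave open how an amine or a carboxylic acid in place of the 1-methyl-1H-tetrazol-5-yl on the sulfur would read in this assay.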